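Swapping an Aromatic Ring for Tert-butyl

The source may hold more compounds than are shown below. What is called first, only, known or untested is meant among the compounds shown, and "the series" means these compounds.

Of the compounds shown here, three that share a core have been measured in a functional assay on PC-9 cells (Homo sapiens) for inhibition, read by MTT assay, with a stated time of 72 h; a lower number here means a stronger inhibitor, a higher number a weaker inhibitor. Compound 1 `CCCCCc1c(C)nc2nc(SCc3ccc(Cl)cc3)nn2c1Nc1cc(-c2ccccc2)[nH]n1` reaches only a limit of the assay, at > 50000 nM. Compound 2 `Cc1cc(Nc2cc(-c3cccs3)[nH]n2)n2nc(SCc3ccc(Br)cc3)nc2n1` gives 4890 nM in this assay. Compound 3 `Cc1cc(Nc2cc(-c3ccc(F)cc3)[nH]n2)n2nc(SCc3ccc(Br)cc3)nc2n1` gives 6210 nM in this assay, the higher of the two actual numbers, though its nearest neighbour, compound 2, sits within the usual scatter of it. Among the compounds with values here, the only single change measured so far is a 1.3-fold higher number from compound 2 to compound 3 (0.10 log units; within the scatter), an exchange of one aromatic ring for another.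

Compound 4 `Cc1cc(Nc2cc(C(C)(C)C)[nH]n2)n2nc(SCc3ccc(Br)cc3)nc2n1` has not yet been measured. It differs from compound 3 as follows: tert-butyl in place of 4-fluorophenyl on an aromatic carbon. Within the data shown here, no measured step trades an aromatic ring for a branched chain, so the step from compound 2 to compound 3 bears on this only loosely, showing that two different aromatic rings at this place gave much the same result. The estimate for compound 4 therefore stays close to compound 3, with wide uncertainty. Compound 4 is expected to give 8000 nM in this assay, between 2500 nM and 30000 nM. This would mean an expected step of a 1.3-fold higher number from compound 3 to compound 4 (0.11 log units; within the scatter), likely within the scatter.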

Compound 4, half-maximal inhibitory concentration: 12400 nM
Estimate against measurement, compound 4: 1.6-fold (0.19 log units) below; the range from low to high includes it.
By their numbers in this assay, from the lowest: compounds 2, 3 and 4 (each within the scatter of the next, the first and the last beyond it). At a limit, above all of these: compound 1.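

In this assay, compound 4 is the only one shown with no ring at this place, and with tert-butyl on the aromatic carbon it still gives a measured number rather than a limit. Replacing 4-fluorophenyl with tert-butyl gives a step that stays within the scatter: a 2.0-fold higher number from compound 3 to compound 4 (0.30 log units; within the scatter), whereas replacing thiophen-2-yl gives a modest step beyond it: a 2.5-fold higher number from compound 2 to compound 4 (0.40 log units; beyond the scatter), so among these three compounds an aromatic ring here is not required for a measurable value. Nothing shown gives a cause for either step.

The compounds shown leave open how a methyl group, an amine or a carboxylic acid would behave on this carbon. They also leave open whether any group at this place can give a much lower number than compounds 2, 3 and 4 do.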